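Working notes: one added methyl on the carbonyl side chain

This account rests on a few compounds, and the source may have more. Where it says the series, first, only, none or still open, it means among the compounds named here.

Measured in a functional assay on A549 cells (Homo sapiens) for inhibition, read by MTT assay, with a stated time of 72 h; on this read-out higher numbers stand for weaker inhibition and lower numbers for stronger inhibition:
- compound 1 `CCC/C=C\C(=O)Nc1cc(Nc2nc3c(c(-c4cn(C)c5ccccc45)n2)CS(=O)(=O)CC3)c(OC)cc1N(C)CCN(C)C` gives 57 nM
- compound 2 `COc1cc(N(C)CCN(C)C)c(NC(=O)C=C(C)C)cc1Nc1nc2c(c(-c3cn(C)c4ccc(F)cc34)n1)CS(=O)(=O)CC2` gives 2140 nM
- compound 3 `CC/C=C\C(=O)Nc1cc(Nc2nc3c(c(-c4cn(C)c5ccc(F)cc45)n2)CS(=O)(=O)CC3)c(OC)cc1N(C)CCN(C)C` gives 5830 nM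

Compound 3 has the highest number of the three, with compound 2 nearest to it and compound 1 furthest. The next compound is compound 4 `CCC/C=C\C(=O)Nc1cc(Nc2nc3c(c(-c4cn(C)c5ccc(F)cc45)n2)CS(=O)(=O)CC3)c(OC)cc1N(C)CCN(C)C`, and its difference from compound 3 is methyl in place of hydrogen on a saturated chain carbon, two bonds along the chain from a double-bonded chain carbon. This turns but-1-en-1-yl into pent-1-en-1-yl.

Within the data shown here, the only measured step at this carbonyl substituent is a 2.7-fold higher number from compound 2 to compound 3 (0.44 log units; beyond the scatter). It is modest and involves a different change, so it suggests a size but not a direction. Compound 1 (57 nM) also carries pent-1-en-1-yl, but its core differs from that of compound 3, so it offers only a weak hint towards a lower number.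

A modest move to a lower number is therefore expected in this assay. The estimated step is a 2.3-fold lower number from compound 3 to compound 4 (0.37 log units; beyond the scatter). For compound 4 the expected value is 2500 nM (estimated range 500 nM to 9000 nM) .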

Compound 4, half-maximal inhibitory concentration: 7570 nM
Estimate against measurement, compound 4: 3.0-fold (0.48 log units) below; the range from low to high includes it.
By their numbers in this assay, from the lowest: compound 1; then compound 2; then compounds 3 and 4 (each within the scatter of the next).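

In this assay, lengthening but-1-en-1-yl to pent-1-en-1-yl on the carbonyl carbon gives no readable change, with a 1.3-fold higher number from compound 3 to compound 4 (0.11 log units; within the scatter). The replacement of 2-methylprop-1-en-1-yl by pent-1-en-1-yl does register, with a 3.5-fold higher number from compound 2 to compound 4 (0.55 log units; beyond the scatter), so at this position the change from 2-methylprop-1-en-1-yl matters more than the added methyl. With pent-1-en-1-yl held constant, the far larger step comes from outside the side chain: fluoro in place of hydrogen on an aromatic carbon gives a 130-fold higher number from compound 1 to compound 4 (2.12 log units; beyond the scatter). No measurement in hand accounts for any of these steps.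

On these data alone, it remains open whether a longer chain such as hex-1-en-1-yl, or a dimethylamino group on the side chain, would shift the number at this position. As far as these compounds go, it is also open whether the side-chain steps keep their size without fluoro.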